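Swapping a chlorophenyl for a tolyl on the shared core

This account rests on a few compounds, and the source may have more. Where it says the series, first, only, none or still open, it means among the compounds named here.

Compound 1 `C[C@H]1CC[C@@H]2[C@@H](OC(=O)[C@]23CC(c2ccc(Cl)cc2)=NO3)[C@]2(C)C(=O)C=C[C@@]12O` stands, in a physicochemical assay for lipophilicity (on this read-out higher numbers stand for higher lipophilicity and lower numbers for lower lipophilicity), at 2.09, level with compound 3 `C[C@H]1CC[C@@H]2[C@@H](OC(=O)[C@]23CC(c2ccccc2Cl)=NO3)[C@]2(C)C(=O)C=C[C@@]12O`, which gives 2.09; together they are the highest of three numbers. Compound 2 `C[C@H]1CC[C@@H]2[C@@H](OC(=O)[C@]23CC(c2ccccc2)=NO3)[C@]2(C)C(=O)C=C[C@@]12O` gives 1.41. The measured steps show a number 0.68 log units lower from compound 1 to compound 2 (beyond the scatter), a number 0.68 log units higher from compound 2 to compound 3 (beyond the scatter) and no change at the digits printed from compound 1 to compound 3 (within the scatter). Compound 4 `Cc1ccccc1C1=NO[C@]2(C1)C(=O)O[C@@H]1[C@H]2CC[C@H](C)[C@]2(O)C=CC(=O)[C@@]12C` is the next step; the change is 2-methylphenyl in place of 4-chlorophenyl on a carbon with a double bond to nitrogen. Among the compounds with values here, no step from a methyl on that ring has been measured, so only the steps involving the chloro bear on it. Since a chloro lifted this assay by a modest amount, a methyl is expected to hold most of that, giving an estimated a number 0.14 log units lower from compound 1 to compound 4 (within the scatter). Compound 4 is therefore expected at 1.95, with a range from 1.6 to 2.3.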

Compound 4, partition coefficient: 1.86
Compound 4: middle estimate off by 0.09 log units, on the high side; the measured number falls inside the stated range.
By their numbers in this assay, from the lowest: compound 2; then compounds 4, 1 and 3 (each within the scatter of the next).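

Methyl in place of hydrogen on the aromatic carbon also moves the reading in this assay, giving a number 0.45 log units higher from compound 2 to compound 4 (beyond the scatter), so a change at this position other than chloro separates from the unsubstituted phenyl. Methyl in place of chloro gives a number 0.23 log units lower from compound 3 to compound 4 (within the scatter), and 2-methylphenyl in place of 4-chlorophenyl gives a number 0.23 log units lower from compound 1 to compound 4 (within the scatter), so neither separates compound 4 from the chloro compounds. Nothing available accounts for these numbers. On these data alone, whether a methoxy or an amine on this ring would follow the methyl remains open, as does how 4-methylphenyl would compare with 2-methylphenyl.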